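Sulfonyl substituent swap: oxane to morpholine

The compounds below may be only part of what the source reports. "The series", "measured", "known", "first", "only" and "open" are said of these compounds alone.

Compound 2 `O=C(NCc1ccc(S(=O)(=O)C2CCOCC2)cc1)N1Cc2ccncc2C1` gives 26 nM in an assay on isolated protein for inhibition of Nicotinamide phosphoribosyltransferase (Homo sapiens), read by mass spectrometry, with stated times of 15 min and 30 min; a higher number here means a weaker inhibitor, a lower number a stronger inhibitor; compound 1 `CCCn1cc(S(=O)(=O)c2ccc(CNC(=O)N3Cc4ccncc4C3)cc2)cn1` gives 17 nM, and the step of a 1.5-fold higher number from compound 1 to compound 2 (0.18 log units; within the scatter) leaves the two within the scatter. Compound 3 `O=C(NCc1ccc(S(=O)(=O)N2CCOCC2)cc1)N1Cc2ccncc2C1` differs from compound 2 by morpholin-4-yl in place of oxan-4-yl on a sulfonyl sulfur. Among the compounds with values here, the only step that bears on this position is the exchange on the sulfonyl sulfur from compound 1 to compound 2, which changed nothing beyond the scatter, so another group of matching size there is expected to move the number little. Compound 3 is therefore estimated at 30 nM, within 10 nM to 90 nM, a step of a 1.2-fold higher number from compound 2 to compound 3 (0.06 log units; within the scatter).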

Compound 3, half-maximal inhibitory concentration: 71 nM
Compound 3: the middle estimate sits 2.4-fold (0.37 log units) below what was measured, within the range that was stated.
By their numbers in this assay, from the lowest: compounds 1 and 2 (each within the scatter of the next); then compound 3.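

The sulfonyl sulfur position is not indifferent in this assay: morpholin-4-yl in place of oxan-4-yl gives a 2.7-fold higher number from compound 2 to compound 3 (0.44 log units; beyond the scatter), although both groups have six heavy atoms and one six-membered non-aromatic ring. Against 1-propyl-1H-pyrazol-4-yl, morpholin-4-yl gives a 4.2-fold higher number from compound 1 to compound 3 (0.62 log units; beyond the scatter), so the match seen between compound 1 and compound 2 does not extend to every group here. No measurement at hand accounts for this rise.

From the compounds shown here alone, it remains open whether the ring nitrogen on the sulfonyl sulfur is enough for the rise or whether the ring oxygen also contributes. Piperidin-1-yl, with that nitrogen and no oxygen, would separate the two.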